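From Diethylamino to Imidazolyl: Estimating Compound 4

A few compounds are considered here, and "the series" means these few. Any claim that something is new, unique, unknown or untested is made for them only; others in the source may bear on it.

Compound 1 `COc1ccc(C(=O)/C=C/c2ccc(Br)cc2)c2c1C=CC(C)(C)O2`: > 10000 nM
Compound 2 `COc1ccc(C(=O)/C=C/c2ccc(-c3ccccc3)cc2)c2c1C=CC(C)(C)O2`: > 10000 nM
Compound 3 `CCN(CC)c1ccc(/C=C/C(=O)c2ccc(OC)c3c2OC(C)(C)C=C3)cc1`: 590 nM

Three compounds sharing one core were tested in a functional assay on HepG2 cells (Homo sapiens) for antiproliferative activity, read by MTT assay, with a stated time of 24 h; on this read-out lower numbers stand for stronger inhibition and higher numbers for weaker inhibition. For compound 1 the result is a limit of the assay, > 10000 nM, not a number. For compound 2 the result is likewise a limit, > 10000 nM. Within the data shown here, compound 3 is the only one with a real number, 590 nM, and so it stands as the single readable point of reference. The step of an at least 16-fold lower number from compound 1 to compound 3 (1.22 log units; beyond the scatter) and the step of an at least 16-fold lower number from compound 2 to compound 3 (1.22 log units; beyond the scatter) both show that putting diethylamino in place of bromo or phenyl on that aromatic carbon moves the result from the limit to a measurable value; the pair of compounds 1 and 2 shows only two limits, which cannot be compared (the limit of > 10000 nM in this assay, at which 2 of the 3 values shown sit).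

Compound 4 `COc1ccc(C(=O)/C=C/c2ccc(-n3ccnc3)cc2)c2c1C=CC(C)(C)O2` is the next variation: 1H-imidazol-1-yl in place of diethylamino on an aromatic carbon. Among the measured compounds shown here, no measured step covers this exact exchange. The two large steps ending at compound 3 suggest that the diethylamino group is tied to the measurable result, and removing it is expected to carry a cost in this assay. Compound 4 is therefore expected to give about 5000 nM, within 1200 nM to 15000 nM, an estimated step of an 8.5-fold higher number from compound 3 to compound 4 (0.93 log units; beyond the scatter), with a fair chance that only a limit is reported.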

Compound 4, half-maximal inhibitory concentration: > 10000 nM
Compound 4: a limit, no number (the forecaster's own chance of this, stated with the estimate: 40%); middle value at least 2.0-fold (0.30 log units) away from the limit.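

In this assay, the exchange of diethylamino for 1H-imidazol-1-yl gives an at least 16-fold higher number from compound 3 to compound 4 (1.22 log units; beyond the scatter), so the one measurable result in this set is lost. The earlier compounds shown here tied that result to diethylamino only by contrast with bromo and phenyl, which carry no nitrogen, whereas this change keeps a nitrogen-bearing group with the same count of 5 heavy atoms at this place on the ring, para to a large group, and still no number is obtained, so neither nitrogen in the group nor the heavy-atom count is enough on its own. Compound 4 gives only a limit of the assay, like compounds 1 and 2, which leaves diethylamino as the only group shown here that gives a number.

The steps from compounds 1 and 2 to compound 4 cannot be read, so any order among these three stays unknown, because each of them gives only a limit: the limit of > 10000 nM in this assay, at which 3 of the 4 values shown sit. Whether a dimethylamino group, a ring amine such as pyrrolidine or morpholine, or a methoxy group at this place would give a number remains open.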